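A few compounds are considered here, and "the series" means these few. Any claim that something is new, unique, unknown or untested is made for them only; others in the source may bear on it.

Compound 1 `CCc1ccc2c(c1)[C@@H](N1CCCCC1=O)[C@H](O)C2(C)C` and compound 3 `CCc1ccc2c(c1)[C@@H](n1ccccc1=O)[C@H](O)C2(C)C` share one core and differ in a single group: a group of 7 heavy atoms (5 carbon, 1 nitrogen, 1 oxygen; one six-membered aromatic ring with 1 hetero atom) in place of a group of 7 heavy atoms (5 carbon, 1 nitrogen, 1 oxygen; one six-membered non-aromatic ring with 1 hetero atom), on a saturated ring carbon. In a functional assay (trachea) for inhibition, with Cavia porcellus as the target (on this read-out higher numbers stand for weaker inhibition and lower numbers for stronger inhibition), compound 1 gives 2780 nM, and compound 3 gives 2170 nM. That exchange made a 1.3-fold lower number from compound 1 to compound 3 (0.11 log units; within the scatter). Compound 2 `CC1(C)c2cc(C(F)(F)F)ccc2[C@@H](N2CCCCC2=O)[C@@H]1O` rests on a different core, and how the two cores differ is not broken down here. In this assay compound 2 gives only a limit, > 20000 nM, which is the limit of > 20000 nM in this assay, at which 1 of the 3 values shown sits. Compound 4 `CC1(C)c2cc(C(F)(F)F)ccc2[C@@H](n2ccccc2=O)[C@@H]1O` is obtained from compound 2 by the same change: a group of 7 heavy atoms (5 carbon, 1 nitrogen, 1 oxygen; one six-membered aromatic ring with 1 hetero atom) in place of a group of 7 heavy atoms (5 carbon, 1 nitrogen, 1 oxygen; one six-membered non-aromatic ring with 1 hetero atom), on a saturated ring carbon. Since that change made a 1.3-fold lower number from compound 1 to compound 3 (0.11 log units; within the scatter), the step that the limit leaves unreadable from compound 2 to compound 4 is expected to be of a similar, small size. Compound 4 is therefore estimated at 25000 nM, with a likely range from 10000 nM to 60000 nM, and it may well again be reported only as a limit.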

Compound 4, half-maximal inhibitory concentration: > 20000 nM
Compound 4 ended at the assay's limit; the forecaster's own chance of this, stated with the estimate: 70%; the middle value lies beyond the limit too.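

Compound 2 and compound 4 both end at a limit, so no step between them can be read: the limit of > 20000 nM in this assay, at which 2 of the 4 values shown sit.

The compounds shown leave open whether the ring exchange changes inhibition at all on the core of compound 2.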